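The source may report more compounds than this note shows. Statements on the series, on what has been measured and on what is new or still open speak of the compounds shown alone.

Measured so far:
compound 1 `CNC(=O)c1cc(Oc2ccc(C(=O)/C=C/c3cccc(Br)c3)cc2)ccn1` — 2870 nM
compound 2 `CNC(=O)c1cc(Oc2ccc(C(=O)/C=C/c3ccc(F)cc3Cl)cc2)ccn1` — 7320 nM

Both numbers come from a functional assay on HepG2 cells (Homo sapiens) for cytotoxicity, read by MTT assay, with a stated time of 72 h; on this read-out lower numbers stand for stronger inhibition and higher numbers for weaker inhibition. Compound 1 holds the lowest of the two numbers. The step to the other measured value is a 2.6-fold higher number from compound 1 to compound 2 (0.41 log units; beyond the scatter), modest but beyond the scatter.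

Compound 3 `CNC(=O)c1cc(Oc2ccc(C(=O)/C=C/c3ccc(Cl)cc3Cl)cc2)ccn1` is not yet measured in this assay. It differs from compound 1 in one place: 2,4-dichlorophenyl in place of 3-bromophenyl on a double-bonded chain carbon bound to a double-bonded chain carbon. For the measured compounds named here, the only measured step that bears on this change is a 2.6-fold higher number from compound 1 to compound 2 (0.41 log units; beyond the scatter), where a 2-chloro-4-fluorophenyl stood in place of 3-bromophenyl. Compound 3 carries a 2,4-dichlorophenyl, which, like the 2-chloro-4-fluorophenyl of compound 2, is a dihalogenated ring; the exchange of one halogen for the other is not covered by any measured step, so no further correction is available.

The expectation for compound 3 is therefore a step in the same direction and of similar size as seen for compound 2, that is a 2.0-fold higher number from compound 1 to compound 3 (0.31 log units; beyond the scatter), a weakening beyond the scatter. Compound 3 is estimated at 5800 nM, with a range from 2600 nM to 13000 nM.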

Compound 3, half-maximal inhibitory concentration: 11700 nM
Estimate against measurement, compound 3: 2.0-fold (0.30 log units) below; the range from low to high includes it.
By their numbers in this assay, from the lowest: compound 1; then compounds 2 and 3 (each within the scatter of the next).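

In this assay, 2,4-dichlorophenyl in place of 3-bromophenyl on a double-bonded chain carbon bound to a double-bonded chain carbon gives a 4.1-fold higher number from compound 1 to compound 3 (0.61 log units; beyond the scatter) and thus a second dihalogenated ring at this place that reads beyond the scatter from the 3-bromophenyl ring, which still holds the lowest number of the three. The exchange on the ring itself, chloro in place of fluoro on an aromatic carbon, gives a 1.6-fold higher number from compound 2 to compound 3 (0.20 log units; within the scatter) and so cannot be told apart from the usual spread of repeats, which means that compound 2 and compound 3 read as equal and the identity of this halogen makes no visible difference here. No accompanying data bear on what lies behind either step.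

The step away from compound 1 changes the halogen, the number of halogens and their placing on the ring all at once, so the compounds shown cannot assign it to any one of these. Also open, going by these compounds, is how a 3-chlorophenyl, a 4-bromophenyl or a ring carrying a methoxy or a dimethylamino group would read at this place against compound 1.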